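A few compounds are considered here, and "the series" means these few. Any claim that something is new, unique, unknown or untested is made for them only; others in the source may bear on it.

Working notes on the series. Two compounds carry numbers in a functional assay on A549 cells (Homo sapiens) for cytotoxicity, read by MTT assay, with a stated time of 72 h; on this read-out higher numbers stand for weaker inhibition and lower numbers for stronger inhibition. Compound 1 `O=C(Nc1ccc(Oc2ccnc3[nH]ccc23)c(F)c1)c1nn(-c2ccc(Cl)c(F)c2)ccc1=O` gives 10300 nM in this assay. Compound 2 `Cc1cc(=O)n(-c2cccc(F)c2)nc1C(=O)Nc1ccc(Oc2ncnc3[nH]ccc23)cc1` gives 34800 nM in this assay, the highest of the two numbers; the nearest is compound 1, which sits lower by a gap that lies beyond the scatter. Within the data shown here, the two compounds differ in more than one place, so no single-point step links them, and the pair shows only that their two values differ.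

Compound 3 `Cc1cc(=O)n(-c2ccc(Br)cc2F)nc1C(=O)Nc1ccc(Oc2ncnc3[nH]ccc23)cc1` is not yet measured. It differs from compound 2 by 4-bromo-2-fluorophenyl in place of 3-fluorophenyl on an aromatic nitrogen. Among the measured compounds shown here, no measured pair isolates this change. A move toward a lower number is expected, in part because compound 1 gives 10300 nM while carrying a dihalogenated phenyl, though its core is not the same. The expected step from compound 2 to compound 3 is a 1.7-fold lower number from compound 2 to compound 3 (0.24 log units; within the scatter), a modest shift close to the edge of the scatter. For compound 3 the estimate in this assay is 20000 nM, with a range from 6000 nM to 60000 nM.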

Compound 3, half-maximal inhibitory concentration: 3770 nM
Estimate against measurement, compound 3: 5.3-fold (0.72 log units) above; measured number below the stated range.
By their numbers in this assay, from the lowest: compound 3; then compound 1; then compound 2.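

Among these compounds, compound 2 and compound 3 give the first single-point step: with the rest of the structure shared, 4-bromo-2-fluorophenyl in place of 3-fluorophenyl on the aromatic nitrogen gives a 9.2-fold lower number from compound 2 to compound 3 (0.97 log units; beyond the scatter) in this assay. The value in this assay therefore depends on the aryl group at this position, which the earlier pair could not show because its two compounds differ in more than one place. The step combines the entry of bromine with a changed fluorine placement, and no information bearing on the reason for the shift is available.

The compounds shown leave open whether the lower number follows the bromine, the changed fluorine placement or the two together, a question that 4-bromophenyl and 2-fluorophenyl on the same aromatic nitrogen, with the rest of compound 2 kept, would address. Also open, on these data alone, is how this position responds to groups outside the halogenated phenyls, such as a phenyl carrying a carboxylic acid or an amine, or a plain alkyl chain in place of the aryl ring.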